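The source may hold more compounds than are shown below. What is called first, only, known or untested is meant among the compounds shown, and "the series" means these compounds.

Measured compounds:
compound 1 `CNCC1(C)CCN(c2c(F)cc3c(=O)c(C(=O)O)cn(C4CC4)c3c2Cl)C1`: 23 ug/mL
compound 2 `CNCC1(C)CCN(c2c(F)cc3c(=O)c(C(=O)O)cn(C4CC4)c3c2OC)C1`: 120 ug/mL
compound 3 `Nc1c(F)c(N2CCC(N)C2)c(Cl)c2c1c(=O)c(C(=O)O)cn2C1CC1`: 59 ug/mL

All three were read in a functional assay on V79 cells (Cricetulus griseus) for cytotoxicity, read by colony formation; a higher number here means a weaker inhibitor, a lower number a stronger inhibitor. Compound 1 gives 23 ug/mL, compound 2 gives 120 ug/mL, and compound 3 gives 59 ug/mL. Within the data shown here, the one single-point step in the set is a 5.2-fold higher number from compound 1 to compound 2 (0.72 log units; beyond the scatter); the change is methoxy in place of chloro on an aromatic carbon. The difference between the core of compound 1 and the core of compound 3 is not broken down here; their values alone show compound 3 with the higher number.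

Compound 4 `COc1c(N2CCC(N)C2)c(F)c(N)c2c(=O)c(C(=O)O)cn(C3CC3)c12` is not yet measured in this assay. It arises from compound 3 by methoxy in place of chloro on an aromatic carbon. Among the measured compounds shown here, this is the same kind of change as the one from compound 1 to compound 2, not the same: around the place, the two differ in that compound 3 carries the group ortho to a 3-aminopyrrolidin-1-yl group and para to an amino group, whereas compound 1 carries it ortho to a 3-methyl-3-((methylamino)methyl)pyrrolidin-1-yl group, with no amino group para. For the measured compounds named here, only one prior instance exists, so the expectation rests on it alone.

Going by the values given here, for compound 4 the step is expected to be a 4.1-fold higher number from compound 3 to compound 4 (0.61 log units; beyond the scatter), in the direction and of about the size of the step from compound 1 to compound 2, because that step a 5.2-fold higher number from compound 1 to compound 2 (0.72 log units; beyond the scatter) is the only measured guide. Compound 4 is therefore estimated at 240 ug/mL, likely within 100 ug/mL to 560 ug/mL.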

Compound 4, half-maximal inhibitory concentration: 100 ug/mL
The estimate for compound 4 lay 2.4-fold (0.38 log units) above the measured number; low and high end bracket the measured number.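

In this assay, methoxy in place of chloro on the core of compound 3 gives a 1.7-fold higher number from compound 3 to compound 4 (0.23 log units; within the scatter), a step that cannot be told apart from repeat scatter. Set beside the earlier step, the size of this change does not carry over unchanged from one core to the other: the same change on two cores in this assay, a 5.2-fold higher number (0.72 log units; beyond the scatter) from compound 1 to compound 2 and a 1.7-fold higher number (0.23 log units; within the scatter) from compound 3 to compound 4, 3.1-fold (0.49 log units) apart, beyond the scatter of two such steps This does not show which structural difference goes with the gap, since compound 3 carries an amino group para to the place and a 3-aminopyrrolidin-1-yl group ortho to it, whereas compound 1 has no such amino group and carries a different group on the pyrrolidine, and two steps cannot separate these features.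

Still open, from the compounds shown here alone, is how the change behaves on a core that keeps the 3-aminopyrrolidin-1-yl group but lacks the amino group, or the reverse, which would test each feature alone. The compounds shown also leave open whether another group at the same place, such as ethoxy or methyl, would follow chloro or methoxy on either core, and whether the difference between the cores would persist for it.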